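Chloro for Nitro: Estimating an Unmeasured Analogue

The source may report more compounds than this note shows. Statements on the series, on what has been measured and on what is new or still open speak of the compounds shown alone.

Compound 1 `N#CC1=C(N)Oc2c(N)cc3nc4ccccc4nc3c2C12C(=O)N(Cc1cnnn1-c1ccc(Cl)cc1)c1ccccc12` is tested in a functional assay on HepG2 cells (Homo sapiens) for antiproliferative activity, read by MTT assay, with a stated time of 48 h; on this read-out lower numbers stand for stronger inhibition and higher numbers for weaker inhibition; there compound 1 gives > 50000 nM, a limit of the assay. Compound 2 `N#CC1=C(N)Oc2c(N)cc3nc4ccccc4nc3c2C12C(=O)N(Cc1cnnn1-c1ccc([N+](=O)[O-])cc1)c1ccccc12` likewise gives a limit, > 50000 nM, in this assay. For the measured compounds named here, compound 3 `N#CC1=C(N)Oc2c(N)cc3nc4ccccc4nc3c2C12C(=O)N(Cc1cnnn1-c1ccc([N+](=O)[O-])cc1[N+](=O)[O-])c1ccccc12` gives 18400 nM in this assay, the only number among the three. The cores of compound 2 and compound 3 differ by nitro in place of hydrogen on an aromatic carbon, a step of an at least 2.7-fold lower number from compound 2 to compound 3 (0.43 log units; beyond the scatter); from compound 1 the step is an at least 2.7-fold lower number from compound 1 to compound 3 (0.43 log units; beyond the scatter). Compound 2 and compound 1 differ by chloro in place of nitro on an aromatic carbon, a change whose step, a step that the two limits leave unreadable from compound 2 to compound 1, both limits hide. Compound 4 `N#CC1=C(N)Oc2c(N)cc3nc4ccccc4nc3c2C12C(=O)N(Cc1cnnn1-c1ccc(Cl)cc1[N+](=O)[O-])c1ccccc12` is not yet measured; it differs from compound 3 by chloro in place of nitro on an aromatic carbon, the same kind of change, though here the place is also meta to a nitro group. With the earlier step unreadable, the expectation leans on compound 3 at 18400 nM alone. Compound 4 is expected to give 35000 nM, an estimated step of a 1.9-fold higher number from compound 3 to compound 4 (0.28 log units; within the scatter), with a real chance of another limit.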

Compound 4, half-maximal inhibitory concentration: > 50000 nM
Compound 4 was reported as a limit (the forecaster's own chance of this, stated with the estimate: 45%); at least 1.4-fold (0.15 log units) between middle value and limit.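

In this assay, chloro in place of nitro on the 2,4-dinitrophenyl group gives an at least 2.7-fold higher number from compound 3 to compound 4 (0.43 log units; beyond the scatter). That step is a bound and not a size, as compound 4 gives a limit. The same change from compound 2 to compound 1 cannot be read, nor can the other steps that join two limits, so whether the change carries from one core to the other stays unknown because the values at both ends are limits: the limit of > 50000 nM in this assay, at which 3 of the 4 values shown sit.

Among the compounds shown, only the 2,4-dinitrophenyl group of compound 3 gives a number. On these data alone, whether an amine, a methoxy group or a carboxylic acid in place of that same nitro would also give a number remains open.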